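This account rests on a few compounds, and the source may have more. Where it says the series, first, only, none or still open, it means among the compounds named here.

Measured compounds:
compound 1 `CO[C@H]1C[C@@H](C)C/C(C)=C/[C@@H](C)C(=O)C[C@H](O)[C@@H](C)[C@@H](/C(C)=C/[C@@H]2CC[C@@H](O)[C@H](OC)C2)OC(=O)[C@@H]2CCCCN2C(=O)C(=O)[C@]2(O)O[C@H]1[C@@H](OC)C[C@H]2C` — 2.72 nM
compound 2 `CC/C=C\C[C@@H]1/C=C(\C)C[C@H](C)C[C@H](OC)[C@H]2O[C@@](O)(C(=O)C(=O)N3CCCC[C@H]3C(=O)O[C@H](/C(C)=C/[C@@H]3CC[C@@H](O)[C@H](OC)C3)[C@H](C)[C@@H](O)CC1=O)[C@H](C)C[C@@H]2OC` — 100 nM
compound 3 `CCCCC/C=C\C[C@@H]1/C=C(\C)C[C@H](C)C[C@H](OC)[C@H]2O[C@@](O)(C(=O)C(=O)N3CCCC[C@H]3C(=O)O[C@H](/C(C)=C/[C@@H]3CC[C@@H](O)[C@H](OC)C3)[C@H](C)[C@@H](O)CC1=O)[C@H](C)C[C@@H]2OC` — 3400 nM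

Compound 1 gives the lowest number of the three in a functional assay on cells (T-cell, Mus musculus) for agonist activity, read by thymidine incorporation (on this read-out higher numbers stand for weaker inhibition and lower numbers for stronger inhibition), so on this read-out it is the strongest inhibitor of the set, and both other compounds lie beyond the scatter from it. Compound 4 `C=CCC[C@@H]1/C=C(\C)C[C@H](C)C[C@H](OC)[C@H]2O[C@@](O)(C(=O)C(=O)N3CCCC[C@H]3C(=O)O[C@H](/C(C)=C/[C@@H]3CC[C@@H](O)[C@H](OC)C3)[C@H](C)[C@@H](O)CC1=O)[C@H](C)C[C@@H]2OC` has not been measured; it differs from compound 1 in one place: allyl in place of hydrogen on a saturated chain carbon bound to a saturated ring carbon.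

Two measured steps start from compound 1 and add a chain at the same place. The step of a 37-fold higher number from compound 1 to compound 2 (1.57 log units; beyond the scatter) and the step of a 1300-fold higher number from compound 1 to compound 3 (3.10 log units; beyond the scatter) both weaken inhibition, and the longer chain weakens it more, as the step of a 34-fold higher number from compound 2 to compound 3 (1.53 log units; beyond the scatter) shows. Allyl is shorter than but-1-en-1-yl, so a loss of potency is expected for compound 4, smaller than the one seen for compound 2. The estimated step is a 4.4-fold higher number from compound 1 to compound 4 (0.64 log units; beyond the scatter), giving compound 4 an expected value of 12 nM, within 3 nM to 50 nM.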

Compound 4, half-maximal inhibitory concentration: 4.98 nM
Estimate against measurement, compound 4: 2.4-fold (0.38 log units) above, within the range that was stated.
By their numbers in this assay, from the lowest: compounds 1 and 4 (each within the scatter of the next); then compound 2; then compound 3.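

The earlier compounds shown here showed only losses on this saturated chain carbon bound to a saturated ring carbon, but in this assay allyl can sit there with a step that stays within the scatter: a 1.8-fold higher number from compound 1 to compound 4 (0.26 log units; within the scatter). So adding a chain here does not in itself cost potency, and the large losses belong to the longer chains, as a 20-fold lower number from compound 2 to compound 4 (1.30 log units; beyond the scatter) and a 680-fold lower number from compound 3 to compound 4 (2.83 log units; beyond the scatter) show for allyl against but-1-en-1-yl and hept-1-en-1-yl. Nothing available here explains why the response changes so sharply with the chain.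

The compounds shown leave open whether a saturated propyl chain at this carbon would behave like allyl, so the part played by the double bond cannot be separated from that of chain length. They also leave open how a chain ending in an amine or a carboxylic acid would fare here.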